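A Thioether in Place of a Hydroxy on the Shared Core

A few compounds are considered here, and "the series" means these few. Any claim that something is new, unique, unknown or untested is made for them only; others in the source may bear on it.

Compound 1 `CCCc1nc(C)c2c(C(C)C)nnc(O)n12` stands at the edge of what a functional assay for inhibition, with Homo sapiens as the target (a higher number here means a weaker inhibitor, a lower number a stronger inhibitor), can report: in this assay compound 1 gives > 48000 nM, which is a limit and not a measured number (the limit of > 48000 nM in this assay, at which 1 of the 2 values shown sits). Compound 2 `CCCc1nnc(O)n2c(CCC)nc(C)c12` carries propyl in place of isopropyl on an aromatic carbon, and in this assay compound 2 gives 16000 nM. That step is an at least 3.0-fold lower number from compound 1 to compound 2 (0.47 log units; beyond the scatter). Compound 3 `CCCc1nc(C)c2c(C(C)C)nnc(SC)n12` is not yet measured and differs from compound 1 in this way: methylsulfanyl in place of hydroxy on an aromatic carbon. Within the data shown here, the single measured step alters a different group, so no measured step bears on the exchange of hydroxy for methylsulfanyl, and its direction in this assay is open. Because compound 1 gives only the limit > 48000 nM, the starting point itself is uncertain. The expected step is an at least 1.2-fold lower number from compound 1 to compound 3 (0.07 log units; that floor lies within the scatter). Compound 3 is estimated at 40000 nM, between 8000 nM and 150000 nM, with a fair chance that this assay again reports only a limit.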

Compound 3, half-maximal inhibitory concentration: > 48000 nM
Compound 3 ended at the assay's limit; the forecaster's own chance of this, stated with the estimate: 55%; middle value at least 1.2-fold (0.07 log units) away from the limit.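

Compound 1 and compound 3 both stop at a limit of this assay and not at a number, so no step between them can be read: the limit of > 48000 nM in this assay, at which 2 of the 3 values shown sit.

From the compounds shown here alone, whether methylsulfanyl in place of hydroxy on the shared core gives a higher or a lower number in this assay stays open.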